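Methoxy in Place of Bromo on the Hydroxyphenyl Arm

This account rests on a few compounds, and the source may have more. Where it says the series, first, only, none or still open, it means among the compounds named here.

Compound 2 `CN(C)CCn1cnnc1-c1cc(Oc2ccc(NC(=O)N/N=C/c3ccc(O)c(Br)c3)cc2F)ccn1` was measured in a functional assay on A549 cells (Homo sapiens) for cytotoxicity, read by MTT assay, with a stated time of 72 h (a lower number here means a stronger inhibitor, a higher number a weaker inhibitor), where compound 2 gives 1370 nM. Its closest neighbour among the measured compounds is compound 1 `CN(C)CCn1cnnc1-c1cc(Oc2ccc(NC(=O)N/N=C/c3cc(C(C)(C)C)cc(C(C)(C)C)c3O)cc2F)ccn1`, which in this assay gives 980 nM; the two values lie within the usual scatter of repeated measurements, so neither compound can be placed ahead of the other. Compound 3 `Cn1ncnc1-c1cc(Oc2ccc(NC(=O)N/N=C/c3ccccc3)cc2F)ccn1` sits in this assay at the limit of > 100000 nM in this assay, at which 1 of the 3 values shown sits, so the result for compound 3, > 100000 nM, is a limit of the assay and not a number.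

Compound 4 `COc1cc(/C=N/NC(=O)Nc2ccc(Oc3ccnc(-c4nncn4CCN(C)C)c3)c(F)c2)ccc1O` has not been measured. It differs from compound 2 in one place: methoxy in place of bromo on an aromatic carbon. The rest of the shared core is kept unchanged.

Among the compounds with values here, no step between two measured compounds that differ in a single place is available, so the expectation for compound 4 rests on what compound 2 and compound 1 show. The step of a 1.5-fold higher number from compound 2 to compound 4 (0.16 log units; within the scatter) is expected to stay within the scatter, or at most slightly beyond it toward a weaker inhibitor, because compound 2 gives 1370 nM and compound 1 gives 980 nM with a quite different substituent pattern on the same arm. For compound 4 the estimated value in this assay is 2000 nM, with a range from 700 nM to 6000 nM.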

Compound 4, half-maximal inhibitory concentration: > 100000 nM
Compound 4 gave a limit, no number; the forecaster's own chance of this, stated with the estimate: 10%; middle value at least 50-fold (1.69 log units) away from the limit.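

Methoxy in place of bromo on an aromatic carbon, ortho to a hydroxy group, brings in this assay an at least 72-fold higher number from compound 2 to compound 4 (1.86 log units; beyond the scatter). This is the first step shown in which only one place changes, and it shows that, with the rest of the shared core kept, the 3-bromo-4-hydroxyphenyl arm does not carry over its activity to the 4-hydroxy-3-methoxyphenyl arm. The result for compound 4 is a limit of the assay and not a number, so the full size of the step cannot be read, and compound 4 now stands at the end of the measurable range: the limit of > 100000 nM in this assay, at which 2 of the 4 values shown sit.

The compounds shown leave open whether the change follows from the loss of bromo or from the entry of methoxy, a question that chloro, methyl or a plain hydrogen on the same carbon would help to separate. They also leave open whether a longer ether such as ethoxy, or methoxy with the hydroxy group replaced by an amine, would behave in the same way on this arm.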